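A second change on the same aromatic carbon

The compounds below may be only part of what the source reports. "The series", "measured", "known", "first", "only" and "open" are said of these compounds alone.

Compound 1 `CC#C[C@H]1CN(S(=O)(=O)c2ccc(N)nc2)CCN1c1ccc(S(=O)(=O)Nc2ccccc2)cc1`: > 399 mL.min-1.g-1, a limit
Compound 2 `CC#C[C@H]1CN(S(=O)(=O)c2ccc(N)nc2)CCN1c1ccc(C(O)(CC#N)C(F)(F)F)cc1`: 57 mL.min-1.g-1

Among the measured compounds shown here, in an ADME assay (liver) for metabolic stability, with Liver microsome (Rattus norvegicus) as the target, using microsomes and NADPH, with a stated time of 30 min (a lower number here means slower removal, a higher number faster removal of the compound), compound 2 holds the only actual number, and the other result, for compound 1, is the limit of > 399 mL.min-1.g-1 in this assay, at which 1 of the 2 values shown sits. Compound 3 `CC#C[C@H]1CN(S(=O)(=O)c2ccc(N)nc2)CCN1c1ccc([C@](O)(CO)C(F)(F)F)cc1` differs from compound 2 as follows: a group of 8 heavy atoms (3 carbon, 2 oxygen, 3 fluorine; no ring) in place of a group of 9 heavy atoms (4 carbon, 1 nitrogen, 1 oxygen, 3 fluorine; no ring), on an aromatic carbon. For the measured compounds named here, the only measured guide is an at least 7.0-fold lower number from compound 1 to compound 2 (0.84 log units; beyond the scatter), which also concerns a group on an aromatic carbon and rests on a limit. It gives weak support for a further fall. The expected change is a 1.6-fold lower number from compound 2 to compound 3 (0.21 log units; within the scatter), probably not beyond the scatter. Compound 3 is estimated at 35 mL.min-1.g-1, with an expected range of 12 mL.min-1.g-1 to 100 mL.min-1.g-1.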

Compound 3, intrinsic clearance in microsomes: < 14 mL.min-1.g-1
Compound 3: only a limit was reported; the forecaster's own chance of this, stated with the estimate: 10%; middle value at least 2.5-fold (0.39 log units) from the limit.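

On this aromatic carbon, 1,2-dihydroxy-1-(trifluoromethyl)ethyl gives an at least 4.0-fold lower number from compound 2 to compound 3 (0.60 log units; beyond the scatter) in this assay and so shows that the number still moves beyond the scatter when neither group carries a ring, which the earlier step could not show. Over both changes the result is an at least 28-fold lower number from compound 1 to compound 3 (1.45 log units; beyond the scatter) and is large. On these data alone, compound 3 gives only a limit, and the full size of the fall stays unknown because of it: the limit of < 14 mL.min-1.g-1 in this assay, at which 1 of the 3 values shown sits.

The compounds shown do not tell which part of the entering group carries the fall. As far as these compounds go, how an amine or a carboxylic acid on this carbon would read also stays open.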